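Working notes: from compound 3 to compound 4

The source may hold more compounds than are shown below. What is called first, only, known or untested is meant among the compounds shown, and "the series" means these compounds.

The three measured compounds share one core and differ only in a single substituent on the aromatic ring. Compound 3 `CC(=O)/C=C/c1cc(C)ccc1O` gives 8000 nM in a functional assay for inhibition, with Oryctolagus cuniculus as the target; a higher number here means a weaker inhibitor, a lower number a stronger inhibitor. Among the three numbers this is the second highest: compound 1 `CC(=O)/C=C/c1cccc(C)c1O` gives 3630 nM, a lower number and the nearest to compound 3, while compound 2 `CC(=O)/C=C/c1cccc(F)c1O` gives 51200 nM, the highest number and the furthest from compound 3.

Compound 4 `CC(=O)/C=C/c1cc(C(C)(C)C)ccc1O` is not yet measured. It differs from compound 3 in one place: tert-butyl in place of methyl on an aromatic carbon.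

Going by the values given here, the only step measured between compounds that differ in one place is a 14-fold higher number from compound 1 to compound 2 (1.15 log units; beyond the scatter), which sets fluoro in place of methyl on an aromatic carbon. Among the compounds with values here, it does not exchange a methyl for a larger alkyl group and so bears only loosely on the present change; no measured step anywhere replaces methyl by tert-butyl. Compounds 1 and 3 carry the same methyl at different places and give numbers that differ beyond the scatter, but this too says nothing about the size of the group.

Within the data shown here, with no directly comparable step, the expected change a 1.1-fold lower number from compound 3 to compound 4 (0.06 log units; within the scatter) for compound 4 in this assay is none beyond the scatter, with a wide range to either side. Compound 4 is therefore estimated at 7000 nM in this assay, with a range from 2000 nM to 25000 nM.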

Compound 4, half-maximal inhibitory concentration: 8000 nM
Compound 4: middle estimate off by 1.1-fold (0.06 log units), on the low side; the measured number falls inside the stated range.
By their numbers in this assay, from the lowest: compound 1; then compounds 3 and 4 (each within the scatter of the next); then compound 2.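

In this assay, tert-butyl in place of methyl on the aromatic carbon para to a hydroxy group gives no change at the digits printed from compound 3 to compound 4 (within the scatter). The earlier compounds shown here carried only methyl at this place, so they gave no reading on group size here; the number now stays the same when 1 heavy atom is replaced by 4 heavy atoms, both groups being alkyl with no hydrogen-bond donors or acceptors. This flat step stands apart from a 14-fold higher number from compound 1 to compound 2 (1.15 log units; beyond the scatter), which involves a different place and a different kind of exchange, so the two steps cannot be set against each other as a comparison of positions or of groups. No measurement in hand explains why this exchange leaves the number unmoved.

The compounds shown leave open whether this place responds to anything other than an alkyl group, such as an amine or a carboxylic acid in place of the methyl of compound 3. They also leave open whether tert-butyl in place of the methyl of compound 1 would be as silent there as it is here.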